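Replacing the 3-Carboxypyridin-2-yl Group on the Shared Core

The source may report more compounds than this note shows. Statements on the series, on what has been measured and on what is new or still open speak of the compounds shown alone.

Among the compounds with values here, compound 3 `O=C(CCCCCCc1ccccc1)c1ncc(-c2ncccc2C(=O)O)o1` is the one member of this small set without a number: in an assay (Rattus norvegicus) for inhibition of Fatty-acid amide hydrolase 1 (Homo sapiens) (on this read-out lower numbers stand for stronger inhibition and higher numbers for weaker inhibition), compound 3 gives only a limit, > 50 nM. Compound 1 `O=C(CCCCCCc1ccccc1)c1ncc(-c2cccc(O)c2)o1` gives 50 nM in this assay, and compound 2 `N#Cc1cccc(-c2cnc(C(=O)CCCCCCc3ccccc3)o2)c1` gives 15 nM. The steps into compound 3 are a number no lower from compound 1 to compound 3 (the limit leaves the size open) and an at least 3.3-fold higher number from compound 2 to compound 3 (0.52 log units; beyond the scatter), both ending at the limit (the limit of > 50 nM in this assay, at which 1 of the 3 values shown sits). Compound 4 `O=C(CCCCCCc1ccccc1)c1ncc(-c2cc(=O)[nH]c(=O)[nH]2)o1` differs from compound 3 by a group of 8 heavy atoms (4 carbon, 2 nitrogen, 2 oxygen; one six-membered aromatic ring with 2 hetero atoms) in place of a group of 9 heavy atoms (6 carbon, 1 nitrogen, 2 oxygen; one six-membered aromatic ring with 1 hetero atom), on an aromatic carbon. Within the data shown here, no measured step tells how far a change away from the 3-carboxypyridin-2-yl group moves the number, so compound 4 is expected to stay near compound 3, with a step that the limit leaves unreadable from compound 3 to compound 4. The estimate for compound 4 is 150 nM, within 40 nM to 1000 nM, and another limit is expected to be likely.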

Compound 4, inhibition constant: 12 nM
Beside the measured number, compound 4's estimate is 13-fold (1.10 log units) above it, and the stated range ends above it.
By their numbers in this assay, from the lowest: compounds 4 and 2 (each within the scatter of the next); then compound 1.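

A change away from the 3-carboxypyridin-2-yl group now has a readable direction in this assay, with an at least 4.1-fold lower number from compound 3 to compound 4 (0.61 log units; beyond the scatter). The entering six-membered aromatic ring with 2 hetero atoms cannot be told apart from the 3-cyanophenyl group, with a 1.3-fold lower number from compound 2 to compound 4 (0.10 log units; within the scatter), yet it separates from the 3-hydroxyphenyl group, with a 4.2-fold lower number from compound 1 to compound 4 (0.62 log units; beyond the scatter). Compound 3 itself remains a limit: the limit of > 50 nM in this assay, at which 1 of the 4 values shown sits.

On these data alone, how far compound 3 lies past that limit stays open. So does whether an amine or a carboxylic acid on the entering ring would keep the number of compound 4 12 nM.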